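Chain length and cytotoxicity in a benzofuran amidine series

This account rests on a few compounds, and the source may have more. Where it says the series, first, only, none or still open, it means among the compounds named here.

The three measured compounds share one core and differ in the linker and in the amidine-type group. Compound 1 `c1ccc(OCCCOc2cccc(-c3cc4cc(C5=NCCN5)ccc4o3)c2)cc1` gives 6500 nM in an ADME assay on L6 cells (Rattus norvegicus) for cytotoxicity, read by resazurin assay, with a stated time of 70 h; on this read-out higher numbers stand for weaker inhibition and lower numbers for stronger inhibition. Compound 2 `CC(C)NC(=N)c1ccc2oc(-c3cccc(OCCCCCOc4ccccc4)c3)cc2c1` gives 10100 nM in this assay. Compound 3 `c1ccc(OCCCCCOc2cccc(-c3cc4cc(C5=NCCN5)ccc4o3)c2)cc1` gives 2600 nM in this assay, the lowest of the three numbers. Two measured steps end at this compound: a 2.5-fold lower number from compound 1 to compound 3 (0.40 log units; beyond the scatter) and a 3.9-fold lower number from compound 2 to compound 3 (0.59 log units; beyond the scatter).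

Compound 4 `c1ccc(OCCCCCCOc2cccc(-c3cc4cc(C5=NCCN5)ccc4o3)c2)cc1` is not yet measured. It differs from compound 3 by phenoxymethyl in place of phenoxy on a saturated chain carbon, five bonds along the chain from an oxygen on an aromatic ring. Of the measured steps, only the lengthening of the chain from compound 1 to compound 3 bears on this change, and that step was a 2.5-fold lower number from compound 1 to compound 3 (0.40 log units; beyond the scatter); the step from compound 2 to compound 3 concerns the other end of the molecule and says nothing about the chain. Compound 4 is therefore expected to give a somewhat lower number than compound 3, by an amount that may not exceed the scatter, as the step from compound 1 to compound 3 covered a larger extension than this one. The expected step is a 1.4-fold lower number from compound 3 to compound 4 (0.16 log units; within the scatter). The estimate for compound 4 in this assay is 1800 nM, with a range from 900 nM to 3600 nM.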

Compound 4, half-maximal inhibitory concentration: 2500 nM
The estimate for compound 4 lay 1.4-fold (0.14 log units) below the measured number; low and high end bracket the measured number.
By their numbers in this assay, from the lowest: compounds 4 and 3 (each within the scatter of the next); then compounds 1 and 2 (each within the scatter of the next).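

In this assay, phenoxymethyl in place of phenoxy on a saturated chain carbon, five bonds along the chain from an oxygen on an aromatic ring, gives a 1.0-fold lower number from compound 3 to compound 4 (0.02 log units; within the scatter), so compound 3 and compound 4 cannot be told apart at this position, and this extension does not add a separation of its own. The separation from compound 1 is beyond the scatter for both chains, at a 2.5-fold lower number from compound 1 to compound 3 (0.40 log units; beyond the scatter) and, with 3-phenoxypropyl in place of phenoxy, at a 2.6-fold lower number from compound 1 to compound 4 (0.41 log units; beyond the scatter), which places the only readable chain effect in this short set between compound 1 and the two longer chains. No measured evidence on the compounds accounts for this flat reading.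

From the compounds shown here alone, a longer chain than that of compound 4 remains open, so the flat reading rests on one pair and may not hold further along. Also open, going by these compounds, is whether an amine or a hydroxyl group placed in the chain would separate from compound 3 and compound 4 in this assay, and whether the group at the other end of compound 2 would show the same flat reading on the chain of compound 4.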